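Moving the Thiophene Attachment Point on Compound 2

The compounds below may be only part of what the source reports. "The series", "measured", "known", "first", "only" and "open" are said of these compounds alone.

Compound 1 `COc1ncnc2c1c(-c1ccsc1)cn2[C@@H]1O[C@H](CO)[C@@H](O)[C@H]1O` gives 7640 nM in a functional assay on CEM-DNR-bulk cells (Homo sapiens), read by MTT assay, with a stated time of 72 h; on this read-out lower numbers stand for stronger inhibition and higher numbers for weaker inhibition.
Compound 2 `CN(C)c1ncnc2c1c(-c1ccsc1)cn2[C@@H]1O[C@H](CO)[C@@H](O)[C@H]1O` gives only a limit of the assay, > 20000 nM.
Compound 3 `Cc1ncnc2c1c(-c1ccsc1)cn2[C@@H]1O[C@H](CO)[C@@H](O)[C@H]1O` gives 8560 nM in this assay.

Compound 2 therefore stands at the top of the numbers shown: it is the one compound that reaches (the limit of > 20000 nM in this assay, at which 1 of the 3 values shown sits), so no exact number is known for it. Against compound 1 the step is an at least 2.6-fold higher number from compound 1 to compound 2 (0.41 log units; beyond the scatter), and against compound 3 it is an at least 2.3-fold lower number from compound 2 to compound 3 (0.36 log units; beyond the scatter), while compounds 1 and 3 differ by a 1.1-fold higher number from compound 1 to compound 3 (0.05 log units; within the scatter).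

Compound 4 `CN(C)c1ncnc2c1c(-c1cccs1)cn2[C@@H]1O[C@H](CO)[C@@H](O)[C@H]1O` keeps the dimethylamino group of compound 2 and changes only the thiophene ring: thiophen-2-yl in place of thiophen-3-yl on an aromatic carbon. None of the three measured steps touches the thiophene; each of them exchanges the group on the aromatic carbon of the shared core. So no measured step bears directly on this change, and the size of its effect has to be taken as unknown. The expectation is a step that the limit leaves unreadable from compound 2 to compound 4, that is, none beyond the scatter. Compound 4 is therefore estimated at 25000 nM, within a range of 9000 nM to 70000 nM, and most likely the assay will again return only a limit.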

Compound 4, half-maximal inhibitory concentration: > 20000 nM
Compound 4 gave a limit, no number; the forecaster's own chance of this, stated with the estimate: 65%; the middle value lies beyond the limit too.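

Compound 2 and compound 4 each return only a limit of the assay, not a number, so the step between them, thiophen-2-yl in place of thiophen-3-yl, cannot be read: the limit of > 20000 nM in this assay, at which 2 of the 4 values shown sit.

The compounds shown leave open whether moving the thiophene attachment point changes the result in this assay at all, and if so, in which direction and by how much.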